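The source may report more compounds than this note shows. Statements on the series, on what has been measured and on what is new or still open speak of the compounds shown alone.

Working notes on the series in a functional assay on A-375 cells (Homo sapiens) for antiproliferative activity, read by MTT assay, with a stated time of 48 h; a higher number here means a weaker inhibitor, a lower number a stronger inhibitor.

The reference point is compound 1 `CCCCCCc1nc(N)n(CC(=O)Nc2ccccc2)c1-c1ccccc1Br`, which in this assay gives 5700 nM. Among the three measured compounds it holds the second highest number: compound 3 `Nc1nc(Cc2ccccc2)c(-c2ccccc2Br)n1CC(=O)Nc1ccccc1` gives 5200 nM, and compound 2 `Nc1nc(CC2CCCCC2)c(-c2ccccc2Br)n1CC(=O)Nc1ccccc1` gives 40600 nM.

Compound 4 `Cc1ccc(Cc2nc(N)n(CC(=O)Nc3ccccc3)c2-c2ccccc2Br)cc1` is the unmeasured analogue. The change from compound 1 is 4-methylphenyl in place of pentyl on a saturated chain carbon bound to an aromatic carbon.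

Going by the values given here, three measured steps bear on it. The closest is a 1.1-fold lower number from compound 1 to compound 3 (0.04 log units; within the scatter), where a ring of the same kind enters at the same place. The step of a 7.1-fold higher number from compound 1 to compound 2 (0.85 log units; beyond the scatter) shows that a saturated ring at this position reads differently, and a 7.8-fold lower number from compound 2 to compound 3 (0.89 log units; beyond the scatter) confirms the gap between the two ring types. Compound 4 carries the aromatic ring of compound 3 with one additional methyl on it; nothing in the measured set speaks to that methyl on its own.

On this basis the step expected for compound 4 is a 1.1-fold lower number from compound 1 to compound 4 (0.06 log units; within the scatter), essentially flat, because a 1.1-fold lower number from compound 1 to compound 3 (0.04 log units; within the scatter) was within the scatter. The estimate for compound 4 in this assay is 5000 nM, with a range from 1800 nM to 14000 nM.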

Compound 4, half-maximal inhibitory concentration: 2500 nM
Compound 4: the middle estimate sits 2.0-fold (0.30 log units) above what was measured; the measured number falls inside the stated range.
By their numbers in this assay, from the lowest: compound 4; then compounds 3 and 1 (each within the scatter of the next); then compound 2.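

In this assay, going by these compounds alone, the methyl group is the first change that can be read on its own: a 2.1-fold lower number from compound 3 to compound 4 (0.32 log units; beyond the scatter) is a step on an aromatic carbon, whereas the earlier steps all changed the group on the saturated chain carbon. With this methyl, the comparison with the pentyl group is no longer flat: a 2.3-fold lower number from compound 1 to compound 4 (0.36 log units; beyond the scatter) stands beyond the scatter, while the unsubstituted phenyl group of compound 3 stayed within it. The gap to the saturated ring also grows, with a 16-fold lower number from compound 2 to compound 4 (1.21 log units; beyond the scatter) as the largest step among these compounds, and no measurement accompanying these values explains any of these differences.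

A single methyl cannot show whether the step belongs to that group alone or would also appear with an ethyl, a methoxy group, a chlorine or a fluorine on the same aromatic carbon. Going by these compounds, the response to an amine or a carboxylic acid on this ring also remains open, as does whether the same order of compounds would hold in any other cell line.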